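Moving a fluorine on the benzyl arm of a D4 ligand series

The compounds below may be only part of what the source reports. "The series", "measured", "known", "first", "only" and "open" are said of these compounds alone.

Of the compounds shown here, three from a single series have been tested in an assay on CHO cells for displacement of a labelled ligand from D(4) dopamine receptor (Homo sapiens), read by radioligand binding; a lower number here means a stronger inhibitor, a higher number a weaker inhibitor. Compound 1, `COc1ccccc1N1CCN(CCCNC(=O)NN(Cc2cccc(F)c2)c2ccc(F)cc2)CC1`, gives 3.8 nM. Compound 2, `COc1ccccc1N1CCN(CCCNC(=O)NN(Cc2ccc(F)cc2)c2ccc(F)cc2)CC1`, differs from compound 1 only by 4-fluorophenyl in place of 3-fluorophenyl on a saturated chain carbon bound to a nitrogen on an aromatic ring. In this assay compound 2 gives 4.6 nM. The step from one to the other is a 1.2-fold higher number from compound 1 to compound 2 (0.08 log units; within the scatter), so the two values are of the same size as far as this measurement can tell. Compound 3, `COc1ccc(N(Cc2cccc(F)c2)NC(=O)NCCCN2CCN(c3ccccc3OC)CC2)cc1`, departs from compound 1 elsewhere, by methoxy in place of fluoro on an aromatic carbon. In this assay compound 3 gives 6.2 nM. The step of a 1.6-fold higher number from compound 1 to compound 3 (0.21 log units; within the scatter) again stays within the scatter, so no order among the three can be read from these numbers.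

Compound 4, `COc1ccc(N(Cc2ccc(F)cc2)NC(=O)NCCCN2CCN(c3ccccc3OC)CC2)cc1`, has not yet been measured in this assay. It stands to compound 3 as compound 2 stands to compound 1: the difference is 4-fluorophenyl in place of 3-fluorophenyl on a saturated chain carbon bound to a nitrogen on an aromatic ring, and the place where it is made is described in the same words in both pairs, so it is the same change carried onto the core of compound 3, whose core differs from that of compound 1 by the methoxy-for-fluoro exchange already described.

Because the step of a 1.2-fold higher number from compound 1 to compound 2 (0.08 log units; within the scatter) was within the scatter, the analogous step is expected to be similarly small, and the estimate for the change from compound 3 to compound 4 is a 1.2-fold higher number from compound 3 to compound 4 (0.08 log units; within the scatter). On that basis compound 4 is expected to give about 7.4 nM in this assay, with a plausible range from 3.5 nM to 16 nM.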

Compound 4, inhibition constant: 2.9 nM
Compound 4: the middle estimate sits 2.6-fold (0.41 log units) above what was measured, and the stated range ends above it.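

In this assay, the change from 3-fluorobenzyl to 4-fluorobenzyl gives a 2.1-fold lower number from compound 3 to compound 4 (0.33 log units; beyond the scatter), and this modest step cannot be told apart from the one seen earlier on the core of compound 1: the same change on two cores in this assay, a 1.2-fold higher number (0.08 log units; within the scatter) from compound 1 to compound 2 and a 2.1-fold lower number (0.33 log units; beyond the scatter) from compound 3 to compound 4, 2.6-fold (0.41 log units) apart, within the scatter of two such steps. The methoxy-for-fluoro exchange, now read on the 4-fluorobenzyl compounds as a 1.6-fold lower number from compound 2 to compound 4 (0.20 log units; within the scatter), likewise shows no measurable dependence on the other position changed: the same change on two cores in this assay, a 1.6-fold higher number (0.21 log units; within the scatter) from compound 1 to compound 3 and a 1.6-fold lower number (0.20 log units; within the scatter) from compound 2 to compound 4, 2.6-fold (0.41 log units) apart, within the scatter of two such steps. Within these four compounds, then, neither change can be said to behave differently from one core to the other, but this does not show that either carries over unchanged, since each comparison rests on a single pair of steps and a real difference of this size could not be separated from the scatter.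

The compounds shown leave open whether the fluorine move would read the same on a core carrying a different group in place of the methoxy or fluoro, such as a nitrile or a trifluoromethyl. They also leave open what a chloro group on the benzyl arm or a longer chain in the shared core would do to the values in this assay.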